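This account rests on a few compounds, and the source may have more. Where it says the series, first, only, none or still open, it means among the compounds named here.

Measured so far in a physicochemical assay for solubility, in phosphate buffer, measured as kinetic solubility, with a stated time of 1 h, at pH 7.4; on this read-out lower numbers stand for lower solubility and higher numbers for higher solubility:
Compound 1 `COc1ccc2nc(C)cc(OCC(=O)Nc3ccccc3)c2c1`, 63000 nM.
Compound 2 `COc1ccc2nc(C)cc(OCC(=O)Nc3c(C)cccc3C)c2c1`, 112000 nM.
Compound 3 `COc1cccc(NC(=O)COc2cc(C)nc3ccc(OC)cc23)c1`, 35000 nM.

Compound 3 carries the lowest of the three numbers in this assay. Its nearest neighbour is compound 1, and that step, a 1.8-fold lower number from compound 1 to compound 3 (0.26 log units; within the scatter), stays within the scatter, so no order between these two is claimed. The step of a 3.2-fold lower number from compound 2 to compound 3 (0.51 log units; beyond the scatter) is beyond the scatter, and compound 2 stands furthest from compound 3.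

Compound 4 `COc1ccc2nc(C)cc(OCC(=O)Nc3cc(C)c(F)c(C)c3)c2c1` is not yet measured. Its change from compound 3 is 4-fluoro-3,5-dimethylphenyl in place of 3-methoxyphenyl on an amide-type nitrogen. Going by the values given here, two measured steps touch the same amide-type nitrogen: a 1.8-fold higher number from compound 1 to compound 2 (0.25 log units; within the scatter), within the scatter, and a 3.2-fold lower number from compound 2 to compound 3 (0.51 log units; beyond the scatter), beyond it. Both leave the methyl-bearing ring of compound 2 with the highest number, while the methoxy-bearing ring of compound 3 sits lowest. Among the compounds with values here, none of the measured rings carries fluorine, so the bearing on compound 4 is indirect. A modest rise is expected for compound 4 in this assay, a 1.6-fold higher number from compound 3 to compound 4 (0.20 log units; within the scatter), because a 3.2-fold lower number from compound 2 to compound 3 (0.51 log units; beyond the scatter) ran the other way when the methoxy-bearing ring replaced a methyl-bearing one. Compound 4 is estimated at 55000 nM, between 18000 nM and 150000 nM.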

Compound 4, solubility: 31500 nM
Beside the measured number, compound 4's estimate is 1.7-fold (0.24 log units) above it; the range from low to high includes it.
By their numbers in this assay, from the lowest: compounds 4, 3, 1 and 2 (each within the scatter of the next, the first and the last beyond it).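

In this assay the 4-fluoro-3,5-dimethylphenyl group on the amide-type nitrogen gives a 1.1-fold lower number from compound 3 to compound 4 (0.05 log units; within the scatter) and a 2.0-fold lower number from compound 1 to compound 4 (0.30 log units; within the scatter) and so cannot be separated from 3-methoxyphenyl or from phenyl at this position. Against 2,6-dimethylphenyl the exchange gives a 3.6-fold lower number from compound 2 to compound 4 (0.55 log units; beyond the scatter) and lies beyond the scatter, which shows that compound 2 and compound 4 can stand apart even though both rings carry two methyl groups; compound 1, with an unsubstituted phenyl ring, stays within the scatter of both compound 2 and compound 4, so the dimethyl-bearing rings do not form a clean pattern against it. Nothing measured on these compounds accounts for any of these steps.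

The separate contributions of the fluorine and the methyl groups remain open, as no ring carrying only one of them appears among the compounds shown. Going by these compounds, all four compounds also share the same core and the same chain to the amide, so the read-out for an amine or a carboxylic acid on the ring, or for a longer chain before the amide carbonyl, remains unknown.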